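The source may report more compounds than this note shows. Statements on the series, on what has been measured and on what is new or still open speak of the compounds shown alone.

Compound 1 `Clc1cccc(-n2ncnc2Cc2ccccc2)c1Cl`: 209 nM
Compound 2 `COc1ccccc1Cn1cnnc1-c1cccc(Cl)c1Cl`: 191 nM
Compound 3 `FC(F)(F)c1ccccc1Cn1cnnc1-c1cccc(Cl)c1Cl`: 132 nM

In a functional assay for antagonist activity at P2X purinoceptor 7 (Homo sapiens) (a higher number here means a weaker inhibitor, a lower number a stronger inhibitor), compound 3 stands within the scatter of both compound 2 and compound 1, so the three compounds cannot be told apart on these numbers. Compound 4 `FC(F)c1ccccc1Cn1cnnc1-c1cccc(Cl)c1Cl` differs from compound 3 by hydrogen in place of fluoro on a saturated chain carbon bound to an aromatic carbon and two fluorine atoms. Among the measured compounds shown here, the only measured step at this part of the molecule, a 1.4-fold lower number from compound 2 to compound 3 (0.16 log units; within the scatter), swapped one whole group for another and stayed within the scatter; no measured step removes a single fluorine from that group. Since the shared core is untouched, the step to compound 4 is expected to be small, a 1.1-fold higher number from compound 3 to compound 4 (0.06 log units; within the scatter), with no direction beyond the scatter. Compound 4 is therefore estimated at 150 nM, between 70 nM and 320 nM.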

Compound 4, half-maximal inhibitory concentration: 117 nM
The estimate for compound 4 lay 1.3-fold (0.11 log units) above the measured number, and the stated range covers the measured number.
By their numbers in this assay, from the lowest: compounds 4, 3, 2 and 1 (each within the scatter of the next).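

Trifluoromethyl to difluoromethyl is the first change shown that removes a single fluorine from this group, and in this assay it gives a 1.1-fold lower number from compound 3 to compound 4 (0.05 log units; within the scatter), so the two groups cannot be told apart. Difluoromethyl in place of methoxy on the same aromatic carbon gives a 1.6-fold lower number from compound 2 to compound 4 (0.21 log units; within the scatter), so these three groups all remain within the scatter of one another. No measurement on hand offers an explanation for this result. Going by these compounds, whether an amine or a carboxylic acid at this place would shift the number beyond the scatter remains open.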